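This account rests on a few compounds, and the source may have more. Where it says the series, first, only, none or still open, it means among the compounds named here.

For the measured compounds named here, compound 1, `COc1ccc(F)cc1CNCCCNc1ccnc2cc(-c3ccc(F)cc3)ccc12`, is the first of the pair that has been measured. In a physicochemical assay for acid dissociation, compound 1 gives 9.47. Compound 2, `COc1ccc(F)cc1CNCCCNc1ccnc2cc(Cc3cc(C)cc(C)c3)ccc12`, differs from it at the far end of the shared core, and in this assay compound 2 gives 9.47. Going by the values given here, the one step that connects the two, no change at the digits printed from compound 1 to compound 2 (within the scatter), is therefore flat: the exchange at the aromatic carbon left the read-out where it was. Compound 2 thus stands level with compound 1 and has no other neighbour among the measured compounds.

Compound 3, `COc1ccc(F)cc1CNCCCNc1ccnc2cc(-c3cccc4ccccc34)ccc12`, is not yet measured. It departs from compound 2 at the same aromatic carbon, (naphthalen-1-yl in place of 3,5-dimethylbenzyl on an aromatic carbon). Among the compounds with values here, the only step that bears on this change is the one from compound 1 to compound 2, no change at the digits printed from compound 1 to compound 2 (within the scatter), which shows that the group on that aromatic carbon did not move the read-out in this assay. On that basis the step from compound 2 to compound 3 is expected to be a number 0.02 log units lower from compound 2 to compound 3 (within the scatter), no change beyond the scatter. Compound 3 is accordingly estimated at 9.45, with a range from 9.15 to 9.75.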

Compound 3, acid dissociation constant: 9.47
Compound 3: the middle estimate sits 0.02 log units below what was measured, and the stated range covers the measured number.
By their numbers in this assay, from the lowest: compounds 1, 2 and 3 (each within the scatter of the next).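

Naphthalen-1-yl in place of 3,5-dimethylbenzyl gives no change at the digits printed from compound 2 to compound 3 (within the scatter) and in place of 4-fluorophenyl gives no change at the digits printed from compound 1 to compound 3 (within the scatter) in this assay on this aromatic carbon of the shared core. The earlier pair showed only that a single exchange left the read-out flat, whereas three different groups on this carbon now read alike, among them the only one with 2 six-membered aromatic rings of carbon only, so the flat result holds for all three compounds shown and for both ways of reaching compound 3. No supporting information is available to explain why the read-out stays level in these compounds.

Going by these compounds, all three groups on this carbon are built of carbon rings, apart from the fluorine of 4-fluorophenyl, so it remains open whether a group of another kind there, such as an amine or a carboxylic acid, would also leave the read-out level. On these data alone, it also remains open what a change away from this carbon would do, for instance a longer chain in place of the one that links the two halves of the molecule.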